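Swapping a Trifluoromethyl for Methoxymethyl on a Weak Binder

A few compounds are considered here, and "the series" means these few. Any claim that something is new, unique, unknown or untested is made for them only; others in the source may bear on it.

Four compounds share a core in which a six-membered non-aromatic ring with two nitrogens carries an amide linked through a three-carbon chain to a piperidine. Compound 1 is `N#Cc1cc(F)ccc1C1CCN(CCCNC(=O)C2=C(C(F)(F)F)NC(=O)N[C@@H]2c2ccc(F)c(F)c2)CC1` and compound 2 is `COCC1=C(C(=O)NCCCN2CCC(c3ccc(F)cc3C#N)CC2)[C@@H](c2ccc(F)c(F)c2)NC(=O)N1`. In an assay on LM cells with Alpha-1B adrenergic receptor (Homo sapiens) as the target (a higher number here means a weaker inhibitor, a lower number a stronger inhibitor), compound 1 gives 200 nM, while compound 2 gives 35 nM. The two differ by methoxymethyl in place of trifluoromethyl on a double-bonded ring carbon, and that change brought a 5.7-fold lower number from compound 1 to compound 2 (0.76 log units; beyond the scatter).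

Compound 3 is `O=C1NC(C(F)(F)F)=C(C(=O)NCCCN2CCC(c3ccccn3)CC2)[C@@H](c2ccc(F)c(F)c2)N1`. It differs from compound 1 in the group on the piperidine, namely (pyridin-2-yl in place of 2-cyano-4-fluorophenyl on a saturated ring carbon). In this assay compound 3 gives only a limit of > 2000 nM. The step of an at least 10-fold higher number from compound 1 to compound 3 (1.00 log units; beyond the scatter) is therefore open-ended, because the limit of > 2000 nM in this assay, at which 1 of the 3 values shown sits, marks the edge of what the measurement resolves.

Compound 4 is `COCC1=C(C(=O)NCCCN2CCC(c3ccccn3)CC2)[C@@H](c2ccc(F)c(F)c2)NC(=O)N1`. It stands to compound 3 as compound 2 stands to compound 1: the change is methoxymethyl in place of trifluoromethyl on a double-bonded ring carbon, and since both place descriptions agree word for word, it is the same change made on a different core. If it acts as it did before, compound 4 is expected to give about 1000 nM in this assay, somewhere between 300 nM and 5000 nM. For compound 4 the expected step is an at least 2.0-fold lower number from compound 3 to compound 4 (0.30 log units; that floor lies within the scatter). This expectation rests on the step of a 5.7-fold lower number from compound 1 to compound 2 (0.76 log units; beyond the scatter), applied to the limit of compound 3, with the caveat that a limit gives no firm starting point, so a second limit is quite possible.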

Compound 4, inhibition constant: 235 nM
Estimate against measurement, compound 4: 4.3-fold (0.63 log units) above; the whole stated range lies above it.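

Compound 3 gives > 2000 nM in this assay, and this is a limit of the assay, not a number. Methoxymethyl in place of trifluoromethyl lowers the number on both cores, and on the core of compound 3 the step is an at least 8.5-fold lower number from compound 3 to compound 4 (0.92 log units; beyond the scatter); set beside the earlier step, the comparison reads: the same change on two cores in this assay, a 5.7-fold lower number (0.76 log units; beyond the scatter) from compound 1 to compound 2 and an at least 8.5-fold lower number (0.92 log units; beyond the scatter) from compound 3 to compound 4; the limit leaves it open whether they differ The change of group on the piperidine also points the same way on both cores, with a 6.7-fold higher number from compound 2 to compound 4 (0.83 log units; beyond the scatter), but two pairs show only a shared direction, not a fixed size for either change or that it would carry to a further core: the same change on two cores in this assay, an at least 10-fold higher number (1.00 log units; beyond the scatter) from compound 1 to compound 3 and a 6.7-fold higher number (0.83 log units; beyond the scatter) from compound 2 to compound 4; the limit leaves it open whether they differ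

The compounds shown leave open whether a hydroxymethyl or a plain methyl on the same double-bonded ring carbon would lower the number as methoxymethyl does. They also leave open whether the same trend would survive a longer chain between the amide and the piperidine.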